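Replacing methyl with carboxy on the aromatic ring

A few compounds are considered here, and "the series" means these few. Any claim that something is new, unique, unknown or untested is made for them only; others in the source may bear on it.

Measured in a functional assay on SK-OV-3 cells (Homo sapiens) for inhibition, read by CCK-8 assay, with a stated time of 70 h; on this read-out lower numbers stand for stronger inhibition and higher numbers for weaker inhibition:
Compound 1 `Clc1ccc(COc2ccc(OCCOCCNC3CCCC3)cc2)cc1` gives 7670 nM
Compound 2 `O=C(O)c1ccccc1COc1ccc(OCCOCCNC2CCCC2)cc1` gives > 100000 nM (a limit of the assay, not a number)
Compound 3 `Cc1ccc(COc2ccc(OCCOCCNC3CCCC3)cc2)cc1` gives 17200 nM

Of the two exact numbers, compound 3 has the higher, and a 2.2-fold higher number from compound 1 to compound 3 (0.35 log units; beyond the scatter) separates it from its nearest neighbour. Compound 4 `O=C(O)c1ccc(COc2ccc(OCCOCCNC3CCCC3)cc2)cc1` differs from compound 3 by carboxy in place of methyl on an aromatic carbon (carboxy in place of methyl on an aromatic carbon, 4-methylphenyl to 4-carboxyphenyl). Among the measured compounds shown here, the closest precedent is the 2-carboxyphenyl group of compound 2. The steps touching it are an at least 13-fold higher number from compound 1 to compound 2 (1.11 log units; beyond the scatter) and an at least 5.8-fold lower number from compound 2 to compound 3 (0.76 log units; beyond the scatter) (both measured against a limit). The carboxy group sits elsewhere on the ring in compound 4, so this precedent transfers only loosely, and compound 4 may also return only a limit, as in the limit of > 100000 nM in this assay, at which 1 of the 3 values shown sits. A move to a higher number, at least modest in size, is therefore expected. The expected step is a 4.1-fold higher number from compound 3 to compound 4 (0.61 log units; beyond the scatter) (an estimate). For compound 4 the estimated value is 70000 nM (expected range 25000 nM to 200000 nM).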

Compound 4, half-maximal inhibitory concentration: > 100000 nM
Compound 4: no number, only a limit; the forecaster's own chance of this, stated with the estimate: 50%; middle value at least 1.4-fold (0.15 log units) from the limit.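

In this assay compound 4 gives > 100000 nM, a limit of the assay and not a number, and so the 4-carboxyphenyl group ends at the same limit as the 2-carboxyphenyl group of compound 2: the limit of > 100000 nM in this assay, at which 2 of the 4 values shown sit. The earlier compounds shown here showed a carboxy group only as 2-carboxyphenyl, whereas here it sits on the aromatic carbon that carries methyl or chloro in the other compounds, giving an at least 5.8-fold higher number from compound 3 to compound 4 (0.76 log units; beyond the scatter) and an at least 13-fold higher number from compound 1 to compound 4 (1.11 log units; beyond the scatter). The step between the two carboxyphenyl compounds cannot be read, so neither placing of the carboxy group can be ranked above the other.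

From the compounds shown here alone, what stays open is whether inhibition would return with a methyl ester or a primary amide on this aromatic carbon. The compounds shown also leave open how a hydroxymethyl group there would compare with methyl.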